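Compound 3 to compound 4: methyl for methoxy

The source may report more compounds than this note shows. Statements on the series, on what has been measured and on what is new or still open speak of the compounds shown alone.

Three compounds on the shared core have readings so far. In a functional assay on MT4 cells (Homo sapiens) for cytotoxicity (a higher number here means a weaker inhibitor, a lower number a stronger inhibitor), compound 1 (`N#Cc1c(N)cccc1Sc1ccc(Cl)cc1`) gives 113000 nM as its reading, and compound 2 (`N#Cc1c(N)cccc1Sc1ccccc1Br`) gives 41000 nM as its reading. Compound 3 (`COc1cccc([S+]([O-])c2cccc(N)c2C#N)c1`) gives > 80000 nM as its reading, which is a limit of the assay and not a number. Compound 3 thus stands at the limit of > 80000 nM in this assay, at which 1 of the 3 values shown sits, and has no exact number of its own.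

Compound 4 (`Cc1cccc([S+]([O-])c2cccc(N)c2C#N)c1`) differs from compound 3 by a single change (methyl in place of methoxy on an aromatic carbon): methyl in place of methoxy on an aromatic carbon, meta to a large group. Among the measured compounds shown here, no measured pair isolates a change of this kind. The expected size of the step in this assay is none beyond the scatter, with no direction favoured. The estimated step of an at least 1.0-fold lower number from compound 3 to compound 4 (0.02 log units; that floor lies within the scatter) is expected to stay within that scatter. The expectation starts from compound 3 at > 80000 nM as a limit. The span it draws on runs from compound 2 at 41000 nM to compound 1 at 113000 nM in the same read-out. Expected for compound 4: 75000 nM as the estimate, within an estimated range of 30000 nM to 150000 nM in this read-out.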

Compound 4, half-maximal inhibitory concentration: > 200000 nM
Compound 4: no number, only a limit (the forecaster's own chance of this, stated with the estimate: 50%); middle value at least 2.6-fold (0.42 log units) from the limit.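

No step can be read between compound 3 and compound 4 in this assay: both readings are limits of the assay and not numbers. The compounds shown leave open what size of change, if any, methyl in place of methoxy on an aromatic carbon brings to this reading on the shared core.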